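Removing a methoxy group from the furan-to-naphthyl series

A few compounds are considered here, and "the series" means these few. Any claim that something is new, unique, unknown or untested is made for them only; others in the source may bear on it.

Of the compounds shown here, three have been measured in a functional assay on HEp-2 cells (Homo sapiens) for cytotoxicity, read by sulforhodamine B assay, with a stated time of 48 h; on this read-out higher numbers stand for weaker inhibition and lower numbers for stronger inhibition. Compound 1 `COc1ccc(C2CC(c3ccco3)=NN2C(C)=O)cc1` gives 15600 nM in this assay. Compound 2 `COc1ccc(C2CC(c3ccco3)=NN2C(C)=O)cc1OC` gives 9990 nM. Compound 3 `COc1ccc(C2CC(c3cccc4ccccc34)=NN2C(C)=O)c(OC)c1OC` gives 1290 nM, the lowest of the three numbers, and its steps to compound 2 and to compound 1 are both beyond the usual scatter. Compound 2 and compound 3 differ in more than one place; the difference between the two cores is not broken down here.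

Compound 4 `COc1ccc(C2CC(c3cccc4ccccc34)=NN2C(C)=O)cc1OC` has not yet been measured in this assay. Its relation to compound 3 is hydrogen in place of methoxy on an aromatic carbon. The same kind of change is already seen between two measured compounds: from compound 2 to compound 1, (hydrogen in place of methoxy on an aromatic carbon), where the place is ortho to a methoxy group and meta to a large group, whereas in compound 3 the place is ortho to a large group, ortho to a methoxy group and meta to a methoxy group. That earlier step gave a 1.6-fold higher number from compound 2 to compound 1 (0.19 log units; within the scatter).

Resting on that step, the change from compound 3 to compound 4 is expected to give a 1.6-fold higher number from compound 3 to compound 4 (0.19 log units; within the scatter) in this assay, because the related change produced only a 1.6-fold higher number from compound 2 to compound 1 (0.19 log units; within the scatter). Compound 4 is therefore estimated at 2000 nM, with a range of 800 nM to 5500 nM, in this assay.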

Compound 4, half-maximal inhibitory concentration: 1030 nM
Compound 4: the middle estimate sits 1.9-fold (0.29 log units) above what was measured, within the range that was stated.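

In this assay, taking away the methoxy group that is ortho to a large group, ortho to a methoxy group and meta to a methoxy group gives a 1.3-fold lower number from compound 3 to compound 4 (0.10 log units; within the scatter), so this pair is not separated by the change, and the naphthalene-bearing compounds stay together at the low end of the numbers shown. Set beside the earlier step on the other core, the result gives no sign that the outcome of this replacement depends on the core: the same change on two cores in this assay, a 1.6-fold higher number (0.19 log units; within the scatter) from compound 2 to compound 1 and a 1.3-fold lower number (0.10 log units; within the scatter) from compound 3 to compound 4, 2.0-fold (0.29 log units) apart, within the scatter of two such steps This shows only that the replacement of methoxy by hydrogen left the number within the scatter on two cores, at a different place on the ring in each; it does not show that the methoxy group is without effect in general, that a small real effect is absent, or that the agreement would hold on a third core or in another assay.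

The compounds shown leave open whether a hydroxyl group, a chlorine atom or an amine at the same place would likewise leave the number within the scatter. They also leave open whether a longer chain, such as ethoxy, would do so, and what happens when every methoxy group on the ring is replaced by hydrogen.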